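Cembranoid ester series: chloromethyl to nitrobenzoyloxymethyl

The source may report more compounds than this note shows. Statements on the series, on what has been measured and on what is new or still open speak of the compounds shown alone.

Of the compounds shown here, two carry numbers so far. In a functional assay on MCF7 cells (Homo sapiens) for antiproliferative activity, read by MTT assay, with a stated time of 48 h (a higher number here means a weaker inhibitor, a lower number a stronger inhibitor), compound 1 `COC/C1=C/C[C@](C)(CCC=C(C)C)/C=C/[C@@H](OC(=O)C=C(C)C)[C@](C)(OC)/C=C/C1=O` gives 16500 nM and compound 2 `CC(C)=CCC[C@]1(C)/C=C/[C@@H](OC(=O)C=C(C)C)[C@](C)(O)/C=C/C(=O)/C(CCl)=C\C1` gives 610 nM. Compound 2 therefore holds the lower of the two numbers; the gap to compound 1 is beyond the scatter. Compound 3 `CC(C)=CCC[C@]1(C)/C=C/[C@@H](OC(=O)C=C(C)C)[C@](C)(O)/C=C/C(=O)/C(COC(=O)c2ccc([N+](=O)[O-])cc2)=C\C1` is unmeasured. Its change from compound 2 is ((4-nitrophenyl)carbonyl)oxy in place of chloro on a saturated chain carbon bound to a double-bonded ring carbon. Among the compounds with values here, no step between measured compounds guides this change, so the step of a 2.0-fold higher number from compound 2 to compound 3 (0.29 log units; within the scatter) is an expectation only, leaning toward a modestly higher number that may still sit within the scatter. Compound 3 is estimated at 1200 nM, between 250 nM and 6000 nM.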

Compound 3, half-maximal inhibitory concentration: 670 nM
Compound 3: the middle estimate sits 1.8-fold (0.25 log units) above what was measured; low and high end bracket the measured number.
By their numbers in this assay, from the lowest: compounds 2 and 3 (each within the scatter of the next); then compound 1.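

In this assay the step of a 1.1-fold higher number from compound 2 to compound 3 (0.04 log units; within the scatter) shows that, on a saturated chain carbon bound to a double-bonded ring carbon, ((4-nitrophenyl)carbonyl)oxy can replace chloro without a shift beyond the scatter. The much larger entering group, with its six-membered aromatic ring of carbon only, therefore leaves the number in place. Nothing available explains this outcome. Open, as far as these compounds go, is whether an amine or a carboxylic acid at this carbon would hold the same level. Also open, from the compounds shown here alone, is what a plain benzoyloxy group, lacking the nitro group, would give.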